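Swapping one small aromatic ring for another on a urea

The source may hold more compounds than are shown below. What is called first, only, known or untested is meant among the compounds shown, and "the series" means these compounds.

Measured compounds:
compound 1, `Cc1cc(C)c(NC(=O)N(Cc2cccc(-c3csc(C)n3)c2)C2CCCCCC2)c(C)c1`, 180 nM
compound 2, `Cc1cc(C)c(NC(=O)N(Cc2ccc(-c3cccs3)cc2)C2CCCCCC2)c(C)c1`, 22 nM
compound 3, `O=C(Nc1c(F)cc(F)cc1F)N(Cc1ccc(-c2ccccn2)cc1)C1CCCCCC1`, 25 nM

In an assay on microsomes from intestine for inhibition of acyl-CoA:cholesterol acyltransferase (Oryctolagus cuniculus) (on this read-out lower numbers stand for stronger inhibition and higher numbers for weaker inhibition), compound 1 gives 180 nM, the highest of the three numbers and thus the weakest inhibition here. Compound 3 sits at 25 nM and compound 2 at 22 nM, both beyond the scatter below compound 1.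

Compound 4, `Cc1cc(C)c(NC(=O)N(Cc2cccc(-c3ccnn3C)c2)C2CCCCCC2)c(C)c1`, differs from compound 1 in a single place: 1-methyl-1H-pyrazol-5-yl in place of 2-methyl-1,3-thiazol-4-yl on an aromatic carbon. Going by the values given here, no measured pair shows this exact swap, so its effect in this assay is not known. Since one small aromatic ring replaces another of a similar kind at the same place, a step of no more than the usual scatter is expected, in either direction. Compound 4 is therefore estimated at 200 nM, within 60 nM to 650 nM. The expected step is a 1.1-fold higher number from compound 1 to compound 4 (0.05 log units; within the scatter).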

Compound 4, half-maximal inhibitory concentration: 35 nM
For compound 4 the middle estimate is 5.7-fold (0.76 log units) above the measured one, outside the stated range (below it).
By their numbers in this assay, from the lowest: compounds 2, 3 and 4 (each within the scatter of the next); then compound 1.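

At this place, meta to a large group, the choice between two five-membered aromatic rings matters: in this assay, 1-methyl-1H-pyrazol-5-yl in place of 2-methyl-1,3-thiazol-4-yl gives a 5.1-fold lower number from compound 1 to compound 4 (0.71 log units; beyond the scatter). The two groups have identical counts of heavy atoms, hydrogen-bond donors and hydrogen-bond acceptors, so these counts do not predict the step. Nothing measured here explains it.

Still open, from the compounds shown here alone, is whether the lower number depends on the methyl group of the new ring. It is also unknown how an amine or a carboxylic acid at this place would compare.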